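A few compounds are considered here, and "the series" means these few. Any claim that something is new, unique, unknown or untested is made for them only; others in the source may bear on it.

Compound 1 `C[Se]/C(=N\C(=O)c1ccco1)NC(=O)c1ccco1` gives 8780 nM in a functional assay on K562 cells (Homo sapiens) for cytotoxicity, read by MTT assay, with a stated time of 72 h; a lower number here means a stronger inhibitor of growth, a higher number a weaker inhibitor of growth. Compound 2 `CS/C(=N\C(=O)c1ccco1)NC(=O)c1ccco1` gives 64800 nM in this assay, the higher of the two numbers, and the change a 7.4-fold higher number from compound 1 to compound 2 (0.87 log units; beyond the scatter) marks that gap. Compound 3 `O=C(/N=C(/NC(=O)c1ccco1)[Se]Cc1ccccc1)c1ccco1` differs from compound 2 by a group of 8 heavy atoms (7 carbon, 1 selenium; one six-membered aromatic ring of carbon only) in place of a group of 2 heavy atoms (1 carbon, 1 sulfur; no ring), on a carbon with a double bond to nitrogen. Within the data shown here, the single step that bears on this change is the one from compound 1 to compound 2, where the switch away from selenium raised the number by a modest but clear margin; the return to selenium, now with a larger group, is expected to run the other way, giving a 6.5-fold lower number from compound 2 to compound 3 (0.81 log units; beyond the scatter). Compound 3 is therefore estimated at 10000 nM, within 3000 nM to 40000 nM.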

Compound 3, concentration for 50% growth inhibition: 9530 nM
The estimate for compound 3 lay 1.0-fold (0.02 log units) above the measured number; the measured number falls inside the stated range.
By their numbers in this assay, from the lowest: compounds 1 and 3 (each within the scatter of the next); then compound 2.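

The step of a 6.8-fold lower number from compound 2 to compound 3 (0.83 log units; beyond the scatter) changes two things at once on the carbon with a double bond to nitrogen, the sulfur and the size of the group, but the second step separates them. With selenium kept, phenyl in place of hydrogen on the saturated chain carbon gives a 1.1-fold higher number from compound 1 to compound 3 (0.04 log units; within the scatter), so in this assay the added ring leaves the number within the scatter and the lower numbers go with selenium in these three compounds. No measurement here gives a reason for this.

The compounds shown leave open whether the same phenyl on the sulfur side would match compound 2 or compound 3. They also leave open how a longer chain, an amine or a carboxylic acid in place of that phenyl would read.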